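Trimming the benzyl of compound 2 to ethyl

The compounds below may be only part of what the source reports. "The series", "measured", "known", "first", "only" and "open" are said of these compounds alone.

Going by the values given here, compound 2 `CCOC(=O)c1cn(Cc2ccccc2)c2cc(Cl)ccc2c1=O` is the only member of this small set with a number of its own: in a functional assay on HEp-2 cells (Homo sapiens) for cytotoxicity, read by MTT assay, with a stated time of 24 h (on this read-out higher numbers stand for weaker inhibition and lower numbers for stronger inhibition), compound 2 gives 19100 nM. Compound 1 `C=CCn1cc(C(=O)OCC)c(=O)c2ccc(Cl)cc21`, by contrast, reaches only a limit of the assay, since in this assay compound 1 gives > 50000 nM. Among the compounds with values here, the single measured step therefore runs from the limit to the number: an at least 2.6-fold lower number from compound 1 to compound 2 (0.41 log units; beyond the scatter), with the upper bound resting on (the limit of > 50000 nM in this assay, at which 1 of the 2 values shown sits).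

Compound 3 `CCOC(=O)c1cn(CC)c2cc(Cl)ccc2c1=O` is reached from compound 2 by methyl in place of phenyl on a saturated chain carbon bound to an aromatic nitrogen. Within the data shown here, this cuts the group on the chain carbon bound to the aromatic nitrogen down further than the vinyl of compound 1, and the one step available points the other way, toward a weaker read-out when the group is smaller. He therefore expects the number in this assay to rise again, with a fair chance that compound 3 returns to the limit rather than yielding a value, so the estimated step is a 2.4-fold higher number from compound 2 to compound 3 (0.37 log units; beyond the scatter). His estimate for compound 3 in this assay is 45000 nM, within a range from 12000 nM to 150000 nM.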

Compound 3, half-maximal inhibitory concentration: > 50000 nM
Compound 3: no number, only a limit (the forecaster's own chance of this, stated with the estimate: 55%); middle value at least 1.1-fold (0.04 log units) away from the limit.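

In this assay compound 3 gives > 50000 nM, which is a limit of the assay and not a number. Set against compound 2, the change from benzyl to ethyl, which puts methyl in place of phenyl on the saturated chain carbon bound to an aromatic nitrogen, gives an at least 2.6-fold higher number from compound 2 to compound 3 (0.41 log units; beyond the scatter), so compound 2 now stands apart from both compound 1 and compound 3 as the only one of the three with a number of its own, and the two replacements for its phenyl, vinyl and methyl, both end at a limit. Compound 1 and compound 3 both sit at that limit, so the step between them cannot be read and vinyl and methyl cannot be set in order at this place: the limit of > 50000 nM in this assay, at which 2 of the 3 values shown sit.

The compounds shown leave open whether the phenyl ring itself is what matters here, a question that cyclohexyl in its place, or a longer chain such as butyl, could begin to answer. They also leave open whether a substituted phenyl, such as one carrying a fluorine or a methoxy group, would move the number in either direction from that of compound 2.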